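Removing the Benzyloxycarbonyl Cap from a Piperazine Dithiocarbamate

The compounds below may be only part of what the source reports. "The series", "measured", "known", "first", "only" and "open" are said of these compounds alone.

Compound 2 `COc1cc(Cn2cc(CSC(=S)N3CCN(C(=O)OCc4ccccc4)CC3)nn2)cc(OC)c1OC` carries a 3,4,5-trimethoxyphenyl group on a saturated chain carbon bound to an aromatic nitrogen. In a functional assay on PC-3 cells (Homo sapiens) for inhibition, read by MTT assay, with a stated time of 72 h (on this read-out lower numbers stand for stronger inhibition and higher numbers for weaker inhibition), compound 2 gives only a limit, > 128000 nM. Its two measured relatives share the same core and differ only in that aryl group: compound 1 `O=C(OCc1ccccc1)N1CCN(C(=S)SCc2cn(Cc3ccc(F)cc3)nn2)CC1` bears a 4-fluorophenyl and compound 3 `O=C(OCc1ccccc1)N1CCN(C(=S)SCc2cn(Cc3ccc(Cl)c(Cl)c3)nn2)CC1` a 3,4-dichlorophenyl. In this assay compound 1 likewise gives only a limit, > 128000 nM. Compound 3 also stops at a limit in this assay, > 128000 nM. Because every value sits at the limit of > 128000 nM in this assay, at which 3 of the 3 values shown sit, the steps a step that the two limits leave unreadable from compound 1 to compound 2, a step that the two limits leave unreadable from compound 1 to compound 3 and a step that the two limits leave unreadable from compound 2 to compound 3 cannot be read for size or direction. Compound 4 `COc1cc(Cn2cc(CSC(=S)N3CCNCC3)nn2)cc(OC)c1OC` is the next step from compound 2: hydrogen in place of benzyloxycarbonyl on an amine nitrogen in a ring. Going by the values given here, none of the measured steps touches this amine nitrogen, and none is readable in size, so no measured step gives a direction here. Compound 4 is therefore expected to stay near the limit, an estimated 100000 nM in this assay, with a range from 30000 nM to 300000 nM. The expected step of an at least 1.2-fold lower number from compound 2 to compound 4 (0.10 log units; that floor lies within the scatter) is thus essentially none beyond the scatter.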

Compound 4, half-maximal inhibitory concentration: > 128000 nM
Compound 4: only a limit was reported; the forecaster's own chance of this, stated with the estimate: 60%; middle value at least 1.2-fold (0.10 log units) away from the limit.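

Going by these compounds alone, compound 4, like compound 2, stops at a limit, so the swap of benzyloxycarbonyl for hydrogen gives no step that can be read for size or direction: the limit of > 128000 nM in this assay, at which 4 of the 4 values shown sit. The compounds shown leave open whether either change, at the aryl group or at the amine nitrogen, alters inhibition in this assay at all.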